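Adding Cyclopropyl to the Amide Nitrogen of Compound 3

The source may hold more compounds than are shown below. What is called first, only, known or untested is meant among the compounds shown, and "the series" means these compounds.

In a functional assay on A549 cells (Homo sapiens) for inhibition, read by sulforhodamine B assay, with a stated time of 72 h (a lower number here means a stronger inhibitor of growth, a higher number a weaker inhibitor of growth), compound 1 `CNC(=O)CCc1ccncc1-c1ccc2ccccc2c1` gives 10400 nM, and compound 2 `COC(=O)/C=C/c1ccncc1-c1ccc2ccccc2c1` gives 760 nM. The measured change between them is a 14-fold lower number from compound 1 to compound 2 (1.14 log units; beyond the scatter). Compound 3 `NC(=O)/C=C/c1ccncc1-c1ccc2ccccc2c1` gives > 10000 nM, which is a limit of the assay and not a number. It therefore stands at the limit of > 10000 nM in this assay, at which 1 of the 3 values shown sits.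

Compound 4 `O=C(/C=C/c1ccncc1-c1ccc2ccccc2c1)NC1CC1` carries cyclopropyl in place of hydrogen on an amide-type nitrogen. The nearest measured change is at the same carbonyl carbon, where amino in place of methoxy gives an at least 13-fold higher number from compound 2 to compound 3 (1.11 log units; beyond the scatter). That change replaces the methoxy group itself, whereas compound 4 keeps the amide. The other comparison, a step that the limit leaves unreadable from compound 1 to compound 3, gives no size. Among the compounds with values here, no measured pair isolates a substituent on the amide nitrogen.

Since compound 1 at 10400 nM also remains weak, compound 4 is expected to stay far closer to the amides than to compound 2 at 760 nM. The expected change is modest: an at least 1.4-fold lower number from compound 3 to compound 4 (0.15 log units; that floor lies within the scatter). Compound 4 is estimated at 7000 nM, with an expected range of 2000 nM to 25000 nM.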

Compound 4, concentration for 50% growth inhibition: 5840 nM
Beside the measured number, compound 4's estimate is 1.2-fold (0.08 log units) above it, within the range that was stated.
By their numbers in this assay, from the lowest: compound 2; then compounds 4 and 1 (each within the scatter of the next).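

In this assay, compound 3 gives only a limit and not a number: the limit of > 10000 nM in this assay, at which 1 of the 4 values shown sits.

Cyclopropyl on the amide-type nitrogen gives this amide a measured number, but the step, an at least 1.7-fold lower number from compound 3 to compound 4 (0.23 log units; that floor lies within the scatter), does not establish a real gain over the unsubstituted amide. Compound 4 also stays clearly apart from the ester, with a 7.7-fold higher number from compound 2 to compound 4 (0.89 log units; beyond the scatter), whereas a 1.8-fold lower number from compound 1 to compound 4 (0.25 log units; within the scatter) means that compound 1 and compound 4 cannot be told apart.

The compounds shown leave open what a longer chain or a phenyl ring on the same nitrogen would do, since cyclopropyl is the only substituent there that can be compared with hydrogen. They also leave open how a carboxylic acid on the same carbonyl carbon would compare with the ester of compound 2.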